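The compounds below may be only part of what the source reports. "The series", "measured", "known", "first", "only" and "open" are said of these compounds alone.

Measured in a functional assay on HCC827 cells (Homo sapiens) for cytotoxicity, read by MTT assay, with a stated time of 72 h; on this read-out lower numbers stand for stronger inhibition and higher numbers for weaker inhibition:

- Compound 1 `C#Cc1cccc(Nc2nc3cnc(Nc4ccc(N5CCN(C)CC5)cc4)nc3n2C2CCCC2)c1`: < 0.01 nM, a limit of the assay and not a number
- Compound 2 `CN1CCN(c2ccc(Nc3ncc4nc(Nc5ccc(Br)cc5)n(C5CCCC5)c4n3)cc2)CC1`: 2.2 nM

Within the data shown here, compound 2 holds the only actual number in this assay, since the one other result is a limit. Compound 3 `CN1CCN(c2ccc(Nc3ncc4nc(Nc5cc(Cl)ccc5Cl)n(C5CCCC5)c4n3)cc2)CC1` keeps the shared core and changes a single group: 2,5-dichlorophenyl in place of 4-bromophenyl on a nitrogen on an aromatic ring. In words, 2,5-dichlorophenyl takes the place of 4-bromophenyl on a nitrogen on an aromatic ring.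

Among the measured compounds shown here, one measured step bears on this change, because it falls at the same place: an at least 220-fold higher number from compound 1 to compound 2 (2.34 log units; beyond the scatter). As far as these compounds go, that step is large, and its full size stays open, as it rests on (the limit of < 0.01 nM in this assay, at which 1 of the 2 values shown sits). It shows that the group at this place can shift the number strongly. However, it swapped a different pair of groups, so it gives no direction for the new one. The central expectation is therefore no step beyond the scatter, with real room for a move either way.

The estimated change is a 1.4-fold higher number from compound 2 to compound 3 (0.13 log units; within the scatter). For compound 3 the expected value is 3 nM, with an estimated range from 0.2 nM to 40 nM.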

Compound 3, half-maximal inhibitory concentration: 0.01 nM
Compound 3: middle estimate off by 300-fold (2.48 log units), on the high side; the whole stated range lies above it.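

In this assay, the change on this nitrogen gives a 220-fold lower number from compound 2 to compound 3 (2.34 log units; beyond the scatter), so the step from 4-bromophenyl to 2,5-dichlorophenyl runs toward stronger inhibition. Among these compounds, the only earlier step at this place, an at least 220-fold higher number from compound 1 to compound 2 (2.34 log units; beyond the scatter), ran the other way, so this position has now moved the number strongly in both directions. The new step also arises between two groups that each hold one six-membered aromatic ring of carbon only and carry no net charge, so a change limited to the halogen atoms on that ring is enough for a large shift. Compound 1 gives < 0.01 nM, a limit of the assay and not a number. The remaining step reads a number no lower from compound 1 to compound 3 (the limit leaves the size open), and its size cannot be read: the limit of < 0.01 nM in this assay, at which 1 of the 3 values shown sits.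

The compounds shown do not separate the swap of bromine for chlorine from the change in the number and places of the halogen atoms, as both differ at once between compound 2 and compound 3. As far as these compounds go, it also remains open how this position would respond to a phenyl ring carrying an amine or a carboxylic acid.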